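The source may hold more compounds than are shown below. What is called first, only, known or untested is meant among the compounds shown, and "the series" means these compounds.

Three compounds share a core built around an amino-triazole carrying a trimethoxyphenyl group and a sulfur-linked side chain. Compound 1 `COc1cc(-c2nnc(SCC(=O)c3ccc(C(F)(F)F)cc3)n2N)cc(OC)c1OC` carries a 4-(trifluoromethyl)phenyl ketone in that side chain, and in a functional assay on HCT-116 cells (Homo sapiens) for antiproliferative activity, read by MTT assay, with a stated time of 48 h (on this read-out lower numbers stand for stronger inhibition and higher numbers for weaker inhibition), compound 1 gives 16700 nM. Compound 2 `COc1cc(-c2nnc(SCC(=O)c3ccc(F)c(F)c3)n2N)cc(OC)c1OC` differs only in the ring on the carbonyl carbon, and in this assay compound 2 gives 10400 nM. The step of a 1.6-fold lower number from compound 1 to compound 2 (0.21 log units; within the scatter) is small. Compound 3 `COc1cc(NC(=O)CSc2nnc(-c3cc(OC)c(OC)c(OC)c3)n2N)cc(OC)c1OC` has an amide in place of the ketone, and in this assay compound 3 reaches only a limit, > 100000 nM. Among the two numbers actually measured, compound 2 stands lowest, with compound 1 close by within the scatter. Compound 4 `COc1cc(-c2nnc(SCC(=O)NCc3ccc(Cl)cc3)n2N)cc(OC)c1OC` is the next compound to be measured in this assay. The change from compound 2 is (4-chlorobenzyl)amino in place of 3,4-difluorophenyl on a carbonyl carbon. Going by the values given here, the only measured step, from compound 1 to compound 2, swapped one ring on the carbonyl for another and stayed within the scatter, so it says little about turning a ketone into an amide. The nearest pointer is compound 3, the one amide measured, which sits at the limit of > 100000 nM in this assay, at which 1 of the 3 values shown sits. Compound 4 is therefore expected to give a higher number than compound 2, with the step of a 3.8-fold higher number from compound 2 to compound 4 (0.59 log units; beyond the scatter), and the estimate for compound 4 is 40000 nM with a range from 12000 nM to 130000 nM.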

Compound 4, half-maximal inhibitory concentration: > 100000 nM
Compound 4: only a limit was reported; the forecaster's own chance of this, stated with the estimate: 35%; middle value at least 2.5-fold (0.39 log units) away from the limit.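

Replacing one ring on the carbonyl carbon with another had stayed within the scatter, but putting (4-chlorobenzyl)amino on that same carbonyl carbon gives a change beyond the scatter, with an at least 9.6-fold higher number from compound 2 to compound 4 (0.98 log units; beyond the scatter) and an at least 5.9-fold higher number from compound 1 to compound 4 (0.77 log units; beyond the scatter). In this assay, the position therefore responds to this change far more than it did to the swap between the 4-(trifluoromethyl)phenyl and 3,4-difluorophenyl ketones, and the one amide seen earlier is no longer alone. Both amides shown, compound 3 and compound 4, reach only a limit and not a number, so the two cannot be ranked against each other and the steps above give only a minimum size: the limit of > 100000 nM in this assay, at which 2 of the 4 values shown sit.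

The compounds shown leave open whether the loss follows the amide link itself or the particular groups it carries, a question that a ketone bearing a 4-chlorobenzyl group would help to settle. Also open, from the compounds shown here alone, is how the position would respond to an amide with a methyl group on its nitrogen in place of the amide hydrogen, or to a carboxylic acid on the same chain.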